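This account rests on a few compounds, and the source may have more. Where it says the series, first, only, none or still open, it means among the compounds named here.

Measured so far:
compound 1, `O=C(COc1ccncc1-c1ccc2ccccc2c1)N1CCOCC1`, 9%
compound 2, `O=C(O)COc1ccncc1-c1ccc2ccccc2c1`, 16%
compound 3, `O=C(/C=C/c1ccncc1-c1ccc2cc[nH]c2c1)N1CCOCC1`, 102%

In an assay on a protein complex for inhibition of CDK8/Cyclin C (Homo sapiens), with a stated time of 1 h, tested at 10 uM (on this read-out higher numbers stand for more inhibition at the one concentration tested (going by the name of the read-out) and lower numbers for less inhibition), compound 1 and compound 2 share a core and differ by hydroxy in place of morpholin-4-yl on a carbonyl carbon; that step, a number 7 percentage points higher from compound 1 to compound 2 (within the scatter), lies within the scatter, so the two numbers cannot be told apart. Compound 3 stands highest, and its gap to the other two is beyond the scatter. How the core of compound 3 differs from the core of compound 1 is not broken down here.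

Compound 4, `O=C(O)/C=C/c1ccncc1-c1ccc2cc[nH]c2c1`, has not been measured. It differs from compound 3 by hydroxy in place of morpholin-4-yl on a carbonyl carbon. Going by the values given here, this is the same kind of change as the one from compound 1 to compound 2, but the surroundings of the place differ: in compound 1 the other neighbour of the carbonyl carbon is a saturated chain carbon, in compound 3 a double-bonded chain carbon.

Because a number 7 percentage points higher from compound 1 to compound 2 (within the scatter) stayed within the scatter, a small step is also expected in this assay from compound 3 to compound 4, about a number 10 percentage points lower from compound 3 to compound 4 (within the scatter). Compound 4 is therefore estimated at 92%, expected between 65% and 105%.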

Compound 4, a percentage reported as inhibition, at one concentration (the size of the read-out at that concentration, not a potency): 103%
The estimate for compound 4 lay 11 percentage points below the measured number; the range from low to high includes it.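

In this assay, putting hydroxy in place of morpholin-4-yl on the carbonyl carbon turns the amide into a carboxy group, and on the core of compound 3 this gives a number 1 percentage points higher from compound 3 to compound 4 (within the scatter). Set beside the earlier case, the change behaves alike on both cores: the same change on two cores in this assay, a number 7 percentage points higher (within the scatter) from compound 1 to compound 2 and a number 1 percentage points higher (within the scatter) from compound 3 to compound 4, 6 percentage points apart, within the scatter of two such steps. This shows that the change carried over between these two cores in this read-out, but two cores are too few to make it a rule, and a number at one concentration is not a potency, so equal numbers do not prove equal potency.

The compounds shown leave open whether other groups on that carbonyl carbon, such as an open-chain amine in place of morpholin-4-yl or a longer chain ending in a carboxylic acid, would fit the same picture. They also leave open which part of the core goes with the high numbers of compound 3 and compound 4.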